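Trichlorophenyl Replacing Phenyl: Expected Effect on Cytotoxicity

The source may report more compounds than this note shows. Statements on the series, on what has been measured and on what is new or still open speak of the compounds shown alone.

Of the compounds shown here, two with a shared core have so far been tested in an ADME assay on CHO cells (Cricetulus griseus) for cytotoxicity, read by MTT assay, with a stated time of 68 h; on this read-out lower numbers stand for stronger inhibition and higher numbers for weaker inhibition. Compound 1 `O=C(/C=C/c1cccc(OCc2ccccc2)c1)c1ccccc1Br` gives 9100 nM, and compound 2 `O=C(/C=C/c1cccc(OCc2ccccc2)c1)c1ccccc1` gives 22000 nM. Compound 2 stands highest of the two numbers, so it inhibits the cells most weakly; the step of a 2.4-fold higher number from compound 1 to compound 2 (0.38 log units; beyond the scatter) shows that replacing bromo with hydrogen on an aromatic carbon weakened the effect. Compound 3 `O=C(/C=C/c1cccc(OCc2ccccc2)c1)c1ccc(Cl)c(Cl)c1Cl` has not yet been measured. It differs from compound 2 by 2,3,4-trichlorophenyl in place of phenyl on a carbonyl carbon. Within the data shown here, the only measured step that bears on this change is a 2.4-fold higher number from compound 1 to compound 2 (0.38 log units; beyond the scatter), which shows that a halogen present in compound 1 goes with a lower number. Since chlorine enters here as part of the 2,3,4-trichlorophenyl group, a lower number is expected for compound 3, with an expected step of a 4.9-fold lower number from compound 2 to compound 3 (0.69 log units; beyond the scatter). Compound 3 is therefore estimated at 4500 nM, with a range from 1500 nM to 13000 nM.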

Compound 3, half-maximal inhibitory concentration: 8600 nM
Compound 3: middle estimate off by 1.9-fold (0.28 log units), on the low side, within the range that was stated.
By their numbers in this assay, from the lowest: compounds 3 and 1 (each within the scatter of the next); then compound 2.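

On the carbonyl carbon, 2,3,4-trichlorophenyl in place of phenyl also goes with a lower number in this assay (a 2.6-fold lower number from compound 2 to compound 3 (0.41 log units; beyond the scatter)), so the link between halogen on this ring and a lower number now holds for chlorine as well as for bromo. Adding more halogen does not go with a further drop, since 2,3,4-trichlorophenyl and 2-bromophenyl cannot be told apart here (a 1.1-fold lower number from compound 1 to compound 3 (0.02 log units; within the scatter)). No other measurement is at hand that would explain either step.

The compounds shown leave open whether all of the chlorine atoms are needed or only some of them, since no compound carries a partly chlorinated ring. They also leave open how this ring would respond to a group without halogen, such as an amine, a carboxylic acid or a methoxy group.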